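The source may report more compounds than this note shows. Statements on the series, on what has been measured and on what is new or still open speak of the compounds shown alone.

In a functional assay on SW480 cells (Homo sapiens) for antiproliferative activity, read by MTT assay, with a stated time of 48 h (a lower number here means a stronger inhibitor, a higher number a weaker inhibitor), compound 1 `O=c1cc(-n2cc(COc3ccccc3)nn2)c2cc(Br)ccc2o1` gives 4990 nM, compound 2 `Nc1ccc(OCc2cn(-c3cc(=O)oc4ccc(Br)cc34)nn2)cc1` gives 2090 nM, and compound 3 `O=c1cc(-n2cc(COc3ccc(Br)cc3)nn2)c2cc(Br)ccc2o1` gives 1310 nM. Compound 3 is set apart from compound 1 by a 3.8-fold lower number from compound 1 to compound 3 (0.58 log units; beyond the scatter), while its gap to compound 2, a 1.6-fold lower number from compound 2 to compound 3 (0.20 log units; within the scatter), is within the scatter, so compounds 2 and 3 are not separated. Compound 4 `O=c1cc(-n2cc(COc3ccc(C(F)(F)F)cc3)nn2)c2cc(Br)ccc2o1` carries trifluoromethyl in place of bromo on an aromatic carbon. Among the compounds with values here, no measured step exchanges one such group for another; the steps that bear on this position are a 3.8-fold lower number from compound 1 to compound 3 (0.58 log units; beyond the scatter) and a 1.6-fold lower number from compound 2 to compound 3 (0.20 log units; within the scatter), both modest or smaller, which gives no ground for a large move in either direction. Compound 4 is therefore expected to give 1500 nM, range 700 nM to 3500 nM, a step of a 1.1-fold higher number from compound 3 to compound 4 (0.06 log units; within the scatter) expected to stay within the scatter.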

Compound 4, half-maximal inhibitory concentration: 3090 nM
Estimate against measurement, compound 4: 2.1-fold (0.31 log units) below; measured number inside the range.
By their numbers in this assay, from the lowest: compounds 3, 2, 4 and 1 (each within the scatter of the next, the first and the last beyond it).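

In this assay, within the data shown here, the exchange on this aromatic carbon is not neutral, with a 2.4-fold higher number from compound 3 to compound 4 (0.37 log units; beyond the scatter) as the only new step beyond the scatter. The lower number seen with bromo over hydrogen does not carry over to trifluoromethyl, which stays unseparated from hydrogen and amino, with a 1.6-fold lower number from compound 1 to compound 4 (0.21 log units; within the scatter) and a 1.5-fold higher number from compound 2 to compound 4 (0.17 log units; within the scatter) both inside the scatter. No measured evidence on this difference between bromo and trifluoromethyl is at hand. Open, on these data alone, is whether chloro, iodo, methoxy or a carboxylic acid on this carbon would track bromo or fall with trifluoromethyl.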